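Replacing a Sulfonyl Group on the Shared Core

This account rests on a few compounds, and the source may have more. Where it says the series, first, only, none or still open, it means among the compounds named here.

Compound 2 `CS(=O)(=O)c1cccc(C(=O)N2CCCC(C(=O)Nc3ccc(Cl)cc3)C2)c1` carries a methylsulfonyl group on its shared core. In an ADME assay on PC-3 cells (Homo sapiens) for cytotoxicity, read by WST assay, tested at 100 uM (a higher number here means more inhibition at the concentration tested (going by the name of the read-out), a lower number less inhibition), compound 2 gives 2%. Its only measured relative, compound 1 `CCN(CC)S(=O)(=O)c1cccc(C(=O)N2CCCC(C(=O)Nc3ccc(Cl)cc3)C2)c1`, gives 0% in this assay, and the two numbers sit within the scatter of each other, so the inhibition in this assay is level between the two.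

The compound not yet measured, compound 3 `CC(C)(C)CC(=O)Nc1cccc(C(=O)N2CCCC(C(=O)Nc3ccc(Cl)cc3)C2)c1`, differs from compound 2 in one place: (neopentylcarbonyl)amino in place of methylsulfonyl on an aromatic carbon.

A single measured step bears on this change: a number 2 percentage points higher from compound 1 to compound 2 (within the scatter), which altered only the substituent on the sulfonyl sulfur. Going by the values given here, no measured step exchanges the whole methylsulfonyl group for a (neopentylcarbonyl)amino group, so the evidence is thin. Both measured compounds show essentially no inhibition. The step from compound 2 to compound 3 is therefore expected to be a number 1 percentage points higher from compound 2 to compound 3 (within the scatter), nothing beyond the scatter. Compound 3 is estimated at 3%, with a range from -10% to 20%.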

Compound 3, a percentage reported as inhibition, at one concentration (the size of the read-out at that concentration, not a potency): 0%
For compound 3 the middle estimate is 3 percentage points above the measured one, within the range that was stated.
By their numbers in this assay, from the lowest: compounds 1, 3 and 2 (each within the scatter of the next).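

Exchanging the whole methylsulfonyl group for (neopentylcarbonyl)amino gives a number 2 percentage points lower from compound 2 to compound 3 (within the scatter) in this assay, and exchanging diethylsulfamoyl for the same group gives no change at the digits printed from compound 1 to compound 3 (within the scatter). The earlier pair differed only on the sulfonyl sulfur, whereas these steps show that the sulfonyl group can leave this aromatic carbon altogether, and an amide with a neopentyl end can take its place, without the reading moving beyond the scatter. Nothing measured here offers an explanation for this flat result.

All three compounds read close to no inhibition, so it remains unclear whether any group on this aromatic carbon can raise the reading at all. Going by these compounds, how an amine, a carboxylic acid or a longer chain would read in this place remains open.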